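The compounds below may be only part of what the source reports. "The series", "measured", "known", "first", "only" and "open" are said of these compounds alone.

Working notes on the series. The shared core is seen in compound 1 `CN1C=CN(C2OC(C(F)(F)F)=CN2c2ccc(S(N)(=O)=O)cc2)C=C1`, compound 2 `CN1C=CN(C2NC(C(Cl)(Cl)Cl)=CN2c2ccc(S(N)(=O)=O)cc2)C=C1` and compound 3 `CN1C=CN(C2OC(C(Cl)(Cl)Cl)=CN2c2ccc(S(N)(=O)=O)cc2)C=C1`. In an ADME assay for inhibition of prostaglandin G/H synthase 1 (Rattus norvegicus), with a stated time of 30 min (a lower number here means a stronger inhibitor, a higher number a weaker inhibitor), compound 1 gives 55600 nM, compound 2 gives 86000 nM and compound 3 gives 53400 nM. Compound 3 holds the lowest of the three numbers, yet its distances to compound 1 and to compound 2 are both within the scatter, so no order among the three can be read. Compound 4 `CC1=CN(c2ccc(S(N)(=O)=O)cc2)C(N2C=CN(C)C=C2)O1` is not yet measured; it differs from compound 3 by methyl in place of trichloromethyl on a double-bonded ring carbon. Among the measured compounds shown here, the only measured step at this double-bonded ring carbon is a 1.0-fold lower number from compound 1 to compound 3 (0.02 log units; within the scatter), a flat exchange of one halogenated group for another; no measured step swaps a halogenated group for a plain methyl, so the present change has no direct precedent. For the measured compounds named here, on the flat behaviour of this position so far, the estimated step is a 1.2-fold higher number from compound 3 to compound 4 (0.06 log units; within the scatter), that is, nothing beyond the scatter. For compound 4 the expected value in this assay is 62000 nM, with a range from 25000 nM to 160000 nM.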

Compound 4, half-maximal inhibitory concentration in the prostaglandin G/H synthase 1 assay: 98600 nM
For compound 4 the middle estimate is 1.6-fold (0.20 log units) below the measured one; low and high end bracket the measured number.
By their numbers in the prostaglandin G/H synthase 1 assay, from the lowest: compounds 3, 1, 2 and 4 (each within the scatter of the next).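

Among the compounds shown here, in the prostaglandin G/H synthase 1 assay, the first exchange of a halogenated group for a plain methyl on this double-bonded ring carbon gives a 1.8-fold higher number from compound 3 to compound 4 (0.27 log units; within the scatter), and the exchange starting from trifluoromethyl gives a 1.8-fold higher number from compound 1 to compound 4 (0.25 log units; within the scatter). Removing the halogens at this position therefore leaves no readable shift in this read-out, so the flat behaviour seen so far now extends to a plain methyl. In a physicochemical assay for lipophilicity (on this read-out higher numbers stand for higher lipophilicity and lower numbers for lower lipophilicity), compound 3 gives 2.41 and compound 4 gives 1.04 as measured values. The same change nevertheless separates two read-outs, since the step in the prostaglandin G/H synthase 1 assay stays within the scatter while the physicochemical assay moves: the measured partition coefficient of compound 3, 2.41, and of compound 4, 1.04, a number 1.37 log units lower (beyond the scatter)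

Going by these compounds, whether another kind of group on this carbon, such as an amine, a carboxylic acid or a longer chain, would move the number in the prostaglandin G/H synthase 1 assay beyond the scatter remains open. Also open, on these data alone, is whether methyl in place of trichloromethyl would read the same on the core of compound 2.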